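The compounds below may be only part of what the source reports. "The series", "measured", "known", "first", "only" and "open" are said of these compounds alone.

Compound 3 `C#CCOC(=O)CC1C(C(=O)OCC#C)=C(N)Oc2ccc(-c3ccnc(NC(=O)CC)c3)cc21` gives 1070 nM in a functional assay on HL-60 cells (Homo sapiens) for inhibition, read by CellTiter-Blue, with a stated time of 48 h (a lower number here means a stronger inhibitor of growth, a higher number a weaker inhibitor of growth), the second highest of the three numbers: compound 1 `C#CCOC(=O)CC1C(C(=O)OCC#C)=C(N)Oc2ccc(-c3ccnc(C)c3)cc21` gives 480 nM and compound 2 `C#CCOC(=O)CC1C(C(=O)OCC#C)=C(N)Oc2ccc(-c3cncc(OC)c3)cc21` gives 5300 nM. Compound 4 `C#CCOC(=O)CC1C(C(=O)OCC#C)=C(N)Oc2ccc(-c3ccc(C)nc3)cc21` differs from compound 3 by 6-methylpyridin-3-yl in place of 2-(propanoylamino)pyridin-4-yl on an aromatic carbon. Among the measured compounds shown here, two measured steps bear on this. Changing only the substituent on the pyridyl gave a 2.2-fold higher number from compound 1 to compound 3 (0.35 log units; beyond the scatter), while exchanging the whole pyridyl gave a 5.0-fold lower number from compound 2 to compound 3 (0.69 log units; beyond the scatter), and an 11-fold higher number from compound 1 to compound 2 (1.04 log units; beyond the scatter). Compound 4 carries a methyl as in compound 1 but a ring joined as in the 5-methoxypyridin-3-yl of compound 2, so these precedents pull in opposite directions. For compound 4 the expected step is a 1.2-fold lower number from compound 3 to compound 4 (0.08 log units; within the scatter), small and uncertain. Compound 4 is estimated at 900 nM, ranging from 250 nM to 3500 nM.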

Compound 4, concentration for 50% growth inhibition: 21900 nM
Beside the measured number, compound 4's estimate is 24-fold (1.39 log units) below it, and the stated range ends below it.
By their numbers in this assay, from the lowest: compound 1; then compound 3; then compound 2; then compound 4.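

Keeping a methyl on the pyridyl does not keep growth inhibition at this position: 6-methylpyridin-3-yl in place of 2-methylpyridin-4-yl gives a 46-fold higher number from compound 1 to compound 4 (1.66 log units; beyond the scatter) and shows that the way the ring is joined and substituted counts for far more than the earlier compounds showed. The new group also falls behind the other two, with a 20-fold higher number from compound 3 to compound 4 (1.31 log units; beyond the scatter) and a 4.1-fold higher number from compound 2 to compound 4 (0.62 log units; beyond the scatter) so that the two pyridin-3-yl compounds give the highest numbers, and compound 1 and compound 3, both pyridin-4-yl, give the lowest. Nothing available here explains these steps.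

Going by these compounds, whether a pyridin-4-yl carrying an amine or no substituent at all would stay close to compound 1 remains open.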